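The source may hold more compounds than are shown below. What is called first, only, known or untested is meant among the compounds shown, and "the series" means these compounds.

Notes on the arylpropanamide series, an assay on CHO cells for antagonist activity at transient receptor potential cation channel subfamily V member 1 (Homo sapiens), read by FLIPR; a lower number here means a stronger inhibitor, a higher number a weaker inhibitor.

Compound 3 `CC(C(=O)NCc1ccc(C(F)(F)F)cc1OC1CCCC1)c1ccc(NS(C)(=O)=O)c(F)c1` gives 0.6 nM in this assay, the lowest of the three numbers recorded so far. Compound 2 `CC(C)COc1cc(C(F)(F)F)ccc1CNC(=O)C(C)c1ccc(NS(C)(=O)=O)c(F)c1` gives 0.8 nM, and compound 1 `CC(C(=O)NCc1ccc(C(F)(F)F)cc1N1CCC(C)(C)CC1)c1ccc(NS(C)(=O)=O)c(F)c1` gives 1.3 nM. The measured steps are a 2.2-fold lower number from compound 1 to compound 3 (0.34 log units; beyond the scatter), a 1.6-fold lower number from compound 1 to compound 2 (0.21 log units; within the scatter) and a 1.3-fold lower number from compound 2 to compound 3 (0.12 log units; within the scatter), so only the change away from the 4,4-dimethylpiperidin-1-yl group has moved the number beyond the scatter.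

The next step is butylsulfanyl in place of cyclopentyloxy on an aromatic carbon, giving compound 4 `CCCCSc1cc(C(F)(F)F)ccc1CNC(=O)C(C)c1ccc(NS(C)(=O)=O)c(F)c1`. The step that bears on it most directly is a 1.3-fold lower number from compound 2 to compound 3 (0.12 log units; within the scatter), where the alkyl group on the ring oxygen was exchanged without a shift beyond the scatter. For the measured compounds named here, no measured pair exchanges the oxygen itself for sulfur, so that part of the change is untested here. On this basis no step beyond the scatter is expected in this assay. For compound 4 the expected step is a 1.5-fold higher number from compound 3 to compound 4 (0.18 log units; within the scatter). Compound 4 is expected to give about 0.9 nM, within a range from 0.3 nM to 3 nM.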

Compound 4, inhibition constant: 1.9 nM
Estimate against measurement, compound 4: 2.1-fold (0.32 log units) below, and the stated range covers the measured number.
By their numbers in this assay, from the lowest: compounds 3, 2, 1 and 4 (each within the scatter of the next, the first and the last beyond it).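

In this assay butylsulfanyl on this aromatic carbon, ortho to a large group, separates from both ethers, with a 3.2-fold higher number from compound 3 to compound 4 (0.50 log units; beyond the scatter) and a 2.4-fold higher number from compound 2 to compound 4 (0.38 log units; beyond the scatter) in the upward direction. Against the 4,4-dimethylpiperidin-1-yl group, the picture differs: a 1.5-fold higher number from compound 1 to compound 4 (0.16 log units; within the scatter) leaves that pair without an order. This change exchanges oxygen for sulfur and also opens the ring of cyclopentyloxy, and nothing measured on the series explains the rise.

How much of the step belongs to the sulfur and how much to the open chain remains unresolved, and a butoxy or a cyclopentylsulfanyl group at this carbon would separate the two. Also open, from the compounds shown here alone, is how a longer thioether chain, such as hexylsulfanyl, would read against butylsulfanyl.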